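The source may hold more compounds than are shown below. What is called first, only, known or untested is meant among the compounds shown, and "the series" means these compounds.

In a toxicity assay on Vero cells (Chlorocebus sabaeus) for cytotoxicity, read by MTT assay (a higher number here means a weaker inhibitor, a lower number a stronger inhibitor), compound 1 (`COC(=O)NC(=O)c1ccsc1NC(=O)c1ccc(S(=O)(=O)N2CCCCCC2)cc1`) gives 9.13 ug/mL and compound 2 (`COC(=O)NC(=O)c1ccsc1NC(=O)c1ccc(S(=O)(=O)N2CCC(C)CC2)cc1`) gives 9.13 ug/mL, while compound 3 (`COC(=O)NC(=O)c1ccsc1NC(=O)c1ccc(S(=O)(=O)N2CCC(OC)CC2)cc1`) gives 18 ug/mL, so all three lie within the scatter of one another. Compound 4 (`COC(=O)NC(=O)c1ccsc1NC(=O)c1ccc(S(=O)(=O)NC2CCOCC2)cc1`) departs from compound 1 with (oxan-4-yl)amino in place of azepan-1-yl on a sulfonyl sulfur. Two measured ring swaps bear on this, no change at the digits printed from compound 1 to compound 2 (within the scatter) and a 2.0-fold higher number from compound 1 to compound 3 (0.29 log units; within the scatter), and the second brings in an oxygen as compound 4 does. Among the measured compounds shown here, none of the measured compounds carries the hydrogen-bond donor that enters. The expected step is a 1.6-fold higher number from compound 1 to compound 4 (0.22 log units; within the scatter), leaning towards a higher number but not beyond the scatter. Compound 4 is expected at 15 ug/mL, with an estimated range of 6 ug/mL to 36 ug/mL.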

Compound 4, half-maximal inhibitory concentration: 35.7 ug/mL
Compound 4: middle estimate off by 2.4-fold (0.38 log units), on the low side, within the range that was stated.
By their numbers in this assay, from the lowest: compounds 1, 2, 3 and 4 (each within the scatter of the next, the first and the last beyond it).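

In this assay, among the compounds shown here, the change to (oxan-4-yl)amino on a sulfonyl sulfur is the first at this position to go beyond the scatter, both against azepan-1-yl (a 3.9-fold higher number from compound 1 to compound 4 (0.59 log units; beyond the scatter)) and against 4-methylpiperidin-1-yl (a 3.9-fold higher number from compound 2 to compound 4 (0.59 log units; beyond the scatter)). Against 4-methoxypiperidin-1-yl it stays within the scatter (a 2.0-fold higher number from compound 3 to compound 4 (0.30 log units; within the scatter)). No measurement at hand accounts for these steps.

The compounds shown leave open whether the higher number goes with the ring oxygen or with the hydrogen on the sulfonamide nitrogen. A cyclohexylamino group on the sulfonyl sulfur would bear on that.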